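Notes on the methoxy-for-methyl step to compound 3

The compounds below may be only part of what the source reports. "The series", "measured", "known", "first", "only" and "open" are said of these compounds alone.

Going by the values given here, compound 2 `CC1=NNC(=O)C1C(c1c(-c2ccccc2)[nH]c2ccc(C)cc12)c1c(-c2ccccc2)[nH]c2ccc(Cl)cc12` is the only member of the set with a number in a functional assay on HEp-2 cells (Homo sapiens) for cytotoxicity, read by MTT assay; a lower number here means a stronger inhibitor, a higher number a weaker inhibitor: compound 2 gives 32400 nM. Compound 1 `CC1=NNC(=O)C1C(c1c(-c2ccccc2)[nH]c2ccc(C)cc12)c1c(-c2ccccc2)[nH]c2ccc(C)cc12` returns > 100000 nM in this assay, and that is a limit rather than a number (the limit of > 100000 nM in this assay, at which 1 of the 2 values shown sits). Among the compounds with values here, the one measured step in the set, an at least 3.0-fold lower number from compound 1 to compound 2 (0.48 log units; beyond the scatter), concerns chloro in place of methyl on an aromatic carbon.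

Compound 3 `COc1ccc2[nH]c(-c3ccccc3)c(C(c3c(-c4ccccc4)[nH]c4ccc(Cl)cc34)C3C(=O)NN=C3C)c2c1` differs from compound 2 by methoxy in place of methyl on an aromatic carbon. Within the data shown here, no measured step in the set involves methoxy, and the single step recorded concerns a different group, so it offers no direct guide to this change; nothing further is known of what methoxy does. The expectation is accordingly for no step beyond the scatter, and the change from compound 2 to compound 3 is estimated as a 1.0-fold lower number from compound 2 to compound 3 (0.01 log units; within the scatter). Compound 3 is thus expected to show 32000 nM in this assay, with an estimated range from 12000 nM to 90000 nM, and a real chance that only a limit is returned.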

Compound 3, half-maximal inhibitory concentration: 6200 nM
Estimate against measurement, compound 3: 5.2-fold (0.71 log units) above; the measured number lies below the stated range.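

In this assay, a 5.2-fold lower number from compound 2 to compound 3 (0.72 log units; beyond the scatter) shows that the aromatic carbon holding the remaining methyl of compound 2 responds to substitution, with a step beyond the scatter. Going by these compounds alone, until this point chloro was the only group seen in place of a methyl; methoxy, which brings an oxygen and one hydrogen-bond acceptor where methyl has none, is a second replacement that lowers the number, and it does so with the chloro of compound 2 kept in place. Nothing measured on these compounds gives a reason for this step.

The compounds shown leave open whether the oxygen or simply the larger group accounts for the step, which a hydroxyl, an ethoxy group or an amine at the same aromatic carbon would help to separate. Within the data shown here, also open is whether methoxy would give a comparable step in place of the chloro that compound 3 keeps, and whether a second methoxy there would add to the one in compound 3.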